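Closing the Amine Side Chain into a Ring

The source may report more compounds than this note shows. Statements on the series, on what has been measured and on what is new or still open speak of the compounds shown alone.

Two compounds share one core and differ only in how two ring positions are arranged. Compound 1 `CCCCc1nc(-c2ccc(Oc3ccc(Cl)cc3)cc2)sc1-c1ccc(OCCCN(CC)CC)cc1` and compound 2 `CCCCc1sc(-c2ccc(Oc3ccc(Cl)cc3)cc2)nc1-c1ccc(OCCCN(CC)CC)cc1` were both tested in an in vitro functional assay on cells (blood brain barrier) for antagonist activity at advanced glycosylation end product-specific receptor (Mus musculus), read by fluorescence, tested at 10 uM; on this read-out lower numbers stand for less inhibition and higher numbers for more inhibition at the one concentration tested (going by the name of the read-out). In this assay compound 1 gives 63.5%, and compound 2 gives 71.7%. These two numbers lie within the usual scatter of each other, so neither compound can be said to inhibit more than the other; compound 2 simply shows the larger of the two figures.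

Compound 3 `CCCCc1sc(-c2ccc(Oc3ccc(Cl)cc3)cc2)nc1-c1ccc(OCC2CCCN(CC)C2)cc1` keeps the arrangement of compound 2 and changes only the amine-bearing side chain: 1-ethylpiperidin-3-yl in place of 2-(diethylamino)ethyl on a saturated chain carbon bound to an oxygen on an aromatic ring. The chain is thus folded into a ring while its single hydrogen-bond acceptor is retained. Within the data shown here, no pair of measured compounds shows what such a change does in this assay, so the step from compound 2 to compound 3 can only be guessed.

The expectation is that compound 3 stays close to compound 2, with a step of a number 3.7 percentage points lower from compound 2 to compound 3 (within the scatter) that is unlikely to exceed the scatter. Compound 3 is therefore estimated at 68%, within a range from 48% to 86%.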

Compound 3, a percentage reported as inhibition, at one concentration (the size of the read-out at that concentration, not a potency): 68.3%
The estimate for compound 3 lay 0.3 percentage points below the measured number; measured number inside the range.
By their numbers in this assay, from the lowest: compounds 1, 3 and 2 (each within the scatter of the next).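

In this assay, folding the open 2-(diethylamino)ethyl group into the 1-ethylpiperidin-3-yl ring gives a number 3.4 percentage points lower from compound 2 to compound 3 (within the scatter). Among these compounds, this is the first measured step at this position, on a saturated chain carbon bound to an oxygen on an aromatic ring, and it cannot be told apart from no change at all. For this one pair, then, the amine can sit either in an open chain or inside a six-membered non-aromatic ring without any readable difference at the single concentration tested.

The compounds shown cover only these two amine-bearing groups, so they leave open whether the same holds for a morpholine ring, a primary amine or a carboxylic acid at this place. They also leave open whether a longer chain between the oxygen and the amine would shift the figure beyond the usual scatter, and whether the ring change would read the same on the arrangement of compound 1. No accompanying measurement offers an explanation for this result.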